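This account rests on a few compounds, and the source may have more. Where it says the series, first, only, none or still open, it means among the compounds named here.

In a functional assay on MGC-803 cells (Homo sapiens) for inhibition, read by MTT assay, with a stated time of 48 h (a higher number here means a weaker inhibitor, a lower number a stronger inhibitor), compound 3 `COc1ccc(CN(C(=O)CN=[N+]=[N-])c2cc(OC)c(OC)c(OC)c2)cc1O` gives 120 nM. This is within the scatter of compound 2 `C/C=C/C(=O)N(Cc1ccc(OC)c(N)c1)c1cc(OC)c(OC)c(OC)c1` at 150 nM, and both values lie far under compound 1 `C/C=C/C(=O)N(Cc1ccc(OC)c(OC)c1)c1cc(OC)c(OC)c(OC)c1` at 20100 nM. The move to compound 4 `C/C=C/C(=O)N(Cc1ccc(OC)c(O)c1)c1cc(OC)c(OC)c(OC)c1` is prop-1-en-1-yl in place of azidomethyl on a carbonyl carbon. Among the measured compounds shown here, no measured step covers this exchange. For the measured compounds named here, the one measured step, a 130-fold lower number from compound 1 to compound 2 (2.13 log units; beyond the scatter), is amino in place of methoxy on an aromatic carbon, so it bears on the exchange only indirectly. It shows a large sensitivity to the aromatic substituent among compounds that carry the incoming prop-1-en-1-yl carbonyl. Compound 4 keeps the aromatic hydroxy of compound 3 and carries the carbonyl group of compound 2. These two compounds sit together in this assay, with compound 3 at 120 nM and compound 2 at 150 nM. Compound 1 at 20100 nM shows that this carbonyl group alone does not secure a low number. The estimated step, a 1.2-fold lower number from compound 3 to compound 4 (0.08 log units; within the scatter), is expected to stay within the scatter. For compound 4 the estimated value is 100 nM, with an expected range of 30 nM to 400 nM.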

Compound 4, half-maximal inhibitory concentration: 27 nM
Estimate against measurement, compound 4: 3.7-fold (0.57 log units) above; measured number below the stated range.
By their numbers in this assay, from the lowest: compound 4; then compounds 3 and 2 (each within the scatter of the next); then compound 1.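

In this assay the carbonyl group now has a measured exchange of its own: prop-1-en-1-yl in place of azidomethyl on a carbonyl carbon gives a 4.4-fold lower number from compound 3 to compound 4 (0.65 log units; beyond the scatter) with the aromatic hydroxy held fixed, so this position is not silent in the series. With the prop-1-en-1-yl carbonyl held fixed, hydroxy in place of amino on an aromatic carbon gives a 5.6-fold lower number from compound 2 to compound 4 (0.74 log units; beyond the scatter) and separates two groups that the earlier data had not compared directly. Hydrogen in place of methyl on an oxygen on an aromatic ring gives a 740-fold lower number from compound 1 to compound 4 (2.87 log units; beyond the scatter) as a large step, so the aromatic substituent remains the bigger lever of the two positions here.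

As far as these compounds go, a longer alkyl chain on the carbonyl carbon and a fluorine or carboxylic acid on the aromatic carbon remain open. Nothing at hand gives a reason for these steps.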